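The source may hold more compounds than are shown below. What is called first, only, known or untested is meant among the compounds shown, and "the series" means these compounds.

Compound 1 `O=S(=O)(/C=C/c1ccccc1)Cc1ccc(Nc2ncnc3ccccc23)cc1`: 5000 nM
Compound 2 `O=S(=O)(/C=C/c1ccc(F)cc1)Cc1ccc(Nc2ncnc3ccccc23)cc1`: 2000 nM

In a functional assay on SK-OV-3 cells (Homo sapiens) (on this read-out lower numbers stand for stronger inhibition of growth and higher numbers for weaker inhibition of growth), compound 2 has the lower number of the two, 2000 nM. Compound 3 `N#Cc1ccc(/C=C/S(=O)(=O)Cc2ccc(Nc3ncnc4ccccc34)cc2)cc1` carries cyano in place of fluoro on an aromatic carbon, para to a large group: cyano in place of fluoro on an aromatic carbon. Among the compounds with values here, one measured step bears on this change, at the same place, and it alone supports the expectation of a small move towards a lower number, perhaps none beyond the scatter: a 2.5-fold lower number from compound 1 to compound 2 (0.40 log units; beyond the scatter). Within the data shown here, no cyano compound has been measured, so the direction remains uncertain. The expected step is a 1.7-fold lower number from compound 2 to compound 3 (0.22 log units; within the scatter). For compound 3 the estimated value is 1200 nM, with an expected range from 400 nM to 4000 nM.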

Compound 3, concentration for 50% growth inhibition: > 100000 nM
Compound 3: no number, only a limit; the forecaster's own chance of this, stated with the estimate: 5%; at least 83-fold (1.92 log units) between middle value and limit.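

In this assay, this place on the aromatic ring, para to a large group, proved far more sensitive than the fluoro step had shown: cyano in place of fluoro gave an at least 50-fold higher number from compound 2 to compound 3 (1.69 log units; beyond the scatter), and cyano in place of hydrogen gave an at least 20-fold higher number from compound 1 to compound 3 (1.30 log units; beyond the scatter). The direction thus depends on the group, since fluoro lowered the number and cyano raised it. Compound 3 gives a limit of the assay, not a number: the limit of > 100000 nM in this assay, at which 1 of the 3 values shown sits.

From the compounds shown here alone, it remains open whether an amine, a carboxylic acid or a methoxy group here would behave like fluoro or like cyano. Going by these compounds, how far the value of compound 3 lies past its limit also remains open.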